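Compound 4: the 1-methylazetidin-3-yl amide

The source may hold more compounds than are shown below. What is called first, only, known or untested is meant among the compounds shown, and "the series" means these compounds.

Values in an ADME assay on microsomes from liver (Mus musculus, strain CD-1) for metabolic stability, read by LC-MS, tested at 2 uM; a lower number here means that the compound disappears faster, a higher number that the compound lasts longer:
- compound 1 `Cn1cc(NC(=O)c2ccncc2Nc2cc(-c3ccc4ccn(C)c4c3)c3nccnc3c2)cn1`: 0.2 h
- compound 2 `Cn1ccc2ccc(-c3cc(Nc4cnccc4C(=O)NC4CCNC(=O)C4)cc4nccnc34)cc21`: > 1 h (a limit)
- compound 3 `Cn1ccc2ccc(-c3cc(Nc4cnccc4C(=O)NCC4COCCN4)cc4nccnc34)cc21`: > 1 h (a limit)

Compound 3 gives no number in this assay: its > 1 h is a limit. The data show (the limit of > 1 h in this assay, at which 2 of the 3 values shown sit).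

Compound 4 `CN1CC(NC(=O)c2ccncc2Nc2cc(-c3ccc4ccn(C)c4c3)c3nccnc3c2)C1` carries 1-methylazetidin-3-yl in place of (morpholin-3-yl)methyl on an amide-type nitrogen.

Three measured steps change the group at this place. Replacing 1-methyl-1H-pyrazol-4-yl gave an at least 5.0-fold higher number from compound 1 to compound 2 (0.69 log units; beyond the scatter) and an at least 5.0-fold higher number from compound 1 to compound 3 (0.69 log units; beyond the scatter). The remaining step is a step that the two limits leave unreadable from compound 2 to compound 3. Going by the values given here, no measured compound carries 1-methylazetidin-3-yl, so the size of its effect is untested. Like compound 2 and compound 3, compound 4 has a non-aromatic ring in place of 1-methyl-1H-pyrazol-4-yl. Given an at least 5.0-fold higher number from compound 1 to compound 3 (0.69 log units; beyond the scatter), a value near the limit rather than near compound 1 is expected in this assay, with no step beyond the scatter. The expected change is a number no higher from compound 3 to compound 4 (the limit leaves the size open). The estimate for compound 4 is 1 h. The expected range for compound 4 runs from 0.4 h to 2.5 h.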

Compound 4, half-life: > 1 h
Compound 4: a limit, no number; the forecaster's own chance of this, stated with the estimate: 55%; the middle value lies on the limit itself.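

In this assay, 1-methylazetidin-3-yl in place of 1-methyl-1H-pyrazol-4-yl gives an at least 5.0-fold higher number from compound 1 to compound 4 (0.69 log units; beyond the scatter), so a third non-aromatic ring on the amide-type nitrogen goes the same way as those of compound 2 and compound 3. The entering group has 0 hydrogen-bond donors, against 1 in (morpholin-3-yl)methyl, so a donor in this group is not required to reach the limit. The steps among compound 2, compound 3 and compound 4 cannot be read, and no order among these three groups follows: the limit of > 1 h in this assay, at which 3 of the 4 values shown sit.

As far as these compounds go, how far each of these three compounds lies past the limit stays open. Also open, from the compounds shown here alone, is whether the ring matters at all or only the loss of 1-methyl-1H-pyrazol-4-yl, which an open-chain dimethylaminoethyl group or a cyclobutyl ring on the same nitrogen would address.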